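Para substituent swap on the aryl ring: methyl to fluoro

A few compounds are considered here, and "the series" means these few. Any claim that something is new, unique, unknown or untested is made for them only; others in the source may bear on it.

For the measured compounds named here, compound 3 `Cc1ccc(-c2cs/c(=N/NC(=O)CSc3ncccn3)n2-c2ccccc2)cc1` stands second highest of the three numbers so far in a functional assay on C6 cells (Rattus norvegicus) for cytotoxicity, read by MTT assay, with a stated time of 24 h, tested at 12 ug/mL (on this read-out lower numbers stand for a stronger effect and higher numbers for a weaker effect at the one concentration tested), where compound 3 gives 83%. Its nearest neighbour is compound 2 `O=C(CSc1ncccn1)N/N=c1/scc(-c2ccc(Cl)cc2)n1-c1ccccc1`, which in this assay gives 91.6%; the two are within the scatter of each other. Furthest away is compound 1 `O=C(CSc1nnnn1-c1ccccc1)N/N=c1/scc(-c2ccc(F)cc2)n1-c1ccccc1`, which in this assay gives 60%, a gap beyond the scatter, though compound 1 differs from the other two in more than one place, so its value is noted without being tied to any single change.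

The step to compound 4 `O=C(CSc1ncccn1)N/N=c1/scc(-c2ccc(F)cc2)n1-c1ccccc1` is fluoro in place of methyl on an aromatic carbon, sitting on an aromatic carbon of a six-membered aromatic ring of carbon only, para to a large group. Going by the values given here, the one measured step at the same position is a number 8.6 percentage points lower from compound 2 to compound 3 (within the scatter), a change between a halogen and methyl that stayed within the scatter. Among the compounds with values here, no measured pair here isolates methyl against fluoro.

On that basis the expected step of a number 3 percentage points higher from compound 3 to compound 4 (within the scatter) is none beyond the scatter, a number near that of compound 3 and compound 2. Compound 4 is therefore estimated at 86%, with a range from 72% to 98%.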

Compound 4, a percentage reported as activity, at one concentration (the size of the read-out at that concentration, not a potency): 77.4%
For compound 4 the middle estimate is 8.6 percentage points above the measured one; the measured number falls inside the stated range.
By their numbers in this assay, from the lowest: compound 1; then compounds 4, 3 and 2 (each within the scatter of the next, the first and the last beyond it).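

Working from this assay, fluoro in place of methyl on this aromatic carbon gives a number 5.6 percentage points lower from compound 3 to compound 4 (within the scatter), whereas fluoro in place of chloro at the same place gives a number 14.2 percentage points lower from compound 2 to compound 4 (beyond the scatter), the first step at this position that lies beyond the scatter. Read with the earlier methyl and chloro step, the three groups do not fall into clean classes: fluoro and chloro separate, while methyl separates from neither of them. The series also gains its first single-place comparison on the sulfur, where, with the 4-fluorophenyl held constant, pyrimidin-2-yl in place of 1-phenyl-1H-tetrazol-5-yl gives a number 17.4 percentage points higher from compound 1 to compound 4 (beyond the scatter), so the low value of compound 1 is now tied to that group; no measurement at hand gives a reason for either step beyond the scatter.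

Open, on these data alone, is whether the change on the sulfur reads the same with methyl or chloro on the aromatic ring, and how a methoxy or an amine in the same place would compare. Also open, as far as these compounds go, is how a simple open chain, such as a butyl group, would read on the sulfur in place of either ring.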